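The source may hold more compounds than are shown below. What is called first, only, known or untested is meant among the compounds shown, and "the series" means these compounds.

Of the compounds shown here, two from this series have been tested in a functional assay on SGC-7901 cells (Homo sapiens) for inhibition, read by MTT assay, with a stated time of 24 h; on this read-out lower numbers stand for stronger inhibition and higher numbers for weaker inhibition. Compound 1 `CC1(C)[C@H]2CC[C@]1(C)N(Cc1cn(-c3cccc(C#N)c3)nn1)C(=O)C2` gives 250 nM in this assay, and compound 2 `CC1(C)[C@H]2CC[C@]1(C)N(Cc1cn(-c3ccc(F)cc3)nn1)C(=O)C2` gives 500 nM in this assay. Among the measured compounds shown here, of the two numbers, compound 2 holds the higher one, but the only step measured so far, a 2.0-fold higher number from compound 1 to compound 2 (0.30 log units; within the scatter), is within the scatter, so the two compounds cannot be told apart on the evidence. That step swapped one aromatic group for another on the same aromatic nitrogen of the shared core, and it moved the number little.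

Compound 3 `CC1(C)[C@H]2CC[C@]1(C)N(Cc1cn(-c3cccc(O)c3)nn1)C(=O)C2` has not yet been measured. It differs from compound 2 in one place: 3-hydroxyphenyl in place of 4-fluorophenyl on an aromatic nitrogen. For the measured compounds named here, the one measured step bears directly on this change, since it also exchanges the aromatic group on that nitrogen, and it stayed within the scatter. A step within the scatter is therefore also expected here, with no clear direction; the estimate for compound 3 in this assay is 400 nM, spanning 150 nM to 1100 nM, which corresponds to an expected step of a 1.3-fold lower number from compound 2 to compound 3 (0.10 log units; within the scatter).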

Compound 3, half-maximal inhibitory concentration: 270 nM
For compound 3 the middle estimate is 1.5-fold (0.17 log units) above the measured one, and the stated range covers the measured number.
By their numbers in this assay, from the lowest: compounds 1, 3 and 2 (each within the scatter of the next).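

Exchanging 4-fluorophenyl for 3-hydroxyphenyl on the aromatic nitrogen gives a 1.9-fold lower number from compound 2 to compound 3 (0.27 log units; within the scatter) in this assay, so a group with a hydrogen-bond donor and a hydrogen-bond acceptor can enter where a group with neither stood, without a change that can be told from the scatter. Hydroxy in place of cyano on an aromatic carbon gives a 1.1-fold higher number from compound 1 to compound 3 (0.03 log units; within the scatter), and with this second comparison the three aromatic groups now tested at this position, 3-cyanophenyl, 4-fluorophenyl and 3-hydroxyphenyl, cannot be separated from one another in this assay. Nothing available here offers an explanation for this flat result.

The compounds shown leave open whether the same holds for a phenyl ring carrying an amine or a carboxylic acid, or for a plain alkyl chain with no aromatic ring on that nitrogen. They also leave open whether any change at this position can move the number by more than the scatter, and so whether this position matters for inhibition of these cells at all.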